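This account rests on a few compounds, and the source may have more. Where it says the series, first, only, none or still open, it means among the compounds named here.

Series notes. Compound 1 `O=C1NN(c2ccc(Cl)cc2)C(=O)/C1=C\c1ccccc1[N+](=O)[O-]`, compound 2 `CN(C)c1ccc([N+](=O)[O-])cc1/C=C1/C(=O)NN(c2ccccc2)C1=O` and compound 3 `CCOC(=O)c1ccc(N2NC(=O)C(=C(C)C)C2=O)cc1` share the same core and have each been run in a toxicity assay on HEK293 cells (Homo sapiens) for cytotoxicity; on this read-out higher numbers stand for weaker inhibition and lower numbers for stronger inhibition. In this assay compound 1 returns only a limit, > 100000 nM. In this assay compound 2 likewise returns only a limit, > 100000 nM. In this assay compound 3 also stops at a limit, > 100000 nM. Compound 2 therefore stands exactly where the rest of the measured set stands: the limit of > 100000 nM in this assay, at which 3 of the 3 values shown sit. Going by the values given here, no pair of measured compounds differing in a single place exists, so no measured step is available to size any change.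

Compound 4 `CN(C)c1ccc([N+](=O)[O-])cc1/C=C1/C(=O)NN(c2cccc(Cl)c2)C1=O` is the next member to be measured. The change from compound 2 is chloro in place of hydrogen on an aromatic carbon; cut one bond further out, the same difference reads phenyl to 3-chlorophenyl. With every measured value in this assay sitting at the limit, the data give no direction for this change. The expected step from compound 2 to compound 4 in this assay is none beyond the scatter, a number no higher from compound 2 to compound 4 (the limit leaves the size open). For compound 4 in this assay the estimate is 100000 nM, with a range from 50000 nM to 200000 nM, and most likely the assay again reports only a limit.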

Compound 4, half-maximal inhibitory concentration: > 100000 nM
Compound 4 was reported as a limit (the forecaster's own chance of this, stated with the estimate: 85%); the middle value lies on the limit itself.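

No step can be read between compound 2 and compound 4 in this assay, as both results are limits. The compounds shown leave open whether chloro in place of hydrogen, or any other change on the shared core, alters this read-out, with the whole set resting at one point: the limit of > 100000 nM in this assay, at which 4 of the 4 values shown sit.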